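Sulfonyl in place of carbamate on the pyrrolidine

The source may hold more compounds than are shown below. What is called first, only, known or untested is meant among the compounds shown, and "the series" means these compounds.

Values in a functional assay on HCC827 cells (Homo sapiens) for antiproliferative activity, read by MTT assay, with a stated time of 72 h (a higher number here means a weaker inhibitor, a lower number a stronger inhibitor), so far:
- compound 1 `CN1CCN(c2ccc(Nc3ncc4nc(Nc5ccccc5)n([C@H]5CCN(S(=O)(=O)C6CC6)C5)c4n3)cc2)CC1` gives 1.6 nM
- compound 2 `CN1CCN(c2ccc(Nc3ncc4nc(Nc5ccc(F)cc5)n([C@@H]5CCN(C(=O)OC(C)(C)C)C5)c4n3)cc2)CC1` gives 27 nM

Compound 2 at 27 nM is the higher of the two numbers, and compound 1 at 1.6 nM lies lower by more than the scatter. Going from compound 2 to compound 3 `CN1CCN(c2ccc(Nc3ncc4nc(Nc5ccc(F)cc5)n([C@H]5CCN(S(=O)(=O)C6CC6)C5)c4n3)cc2)CC1` the structure changes by 1-(cyclopropylsulfonyl)pyrrolidin-3-yl in place of 1-(tert-butoxycarbonyl)pyrrolidin-3-yl on an aromatic nitrogen with 1-(cyclopropylsulfonyl)pyrrolidin-3-yl in place of 1-(tert-butoxycarbonyl)pyrrolidin-3-yl on an aromatic nitrogen. Going by the values given here, no measured pair shows this change alone. Compound 1 also carries 1-(cyclopropylsulfonyl)pyrrolidin-3-yl and gives 1.6 nM as its value, so a lower number, beyond the scatter, is expected for compound 3 in this assay on this thin basis. The expected size is a 9.0-fold lower number from compound 2 to compound 3 (0.95 log units; beyond the scatter) in this estimate. Compound 3 is estimated at 3 nM with 0.8 nM to 12 nM as the expected range.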

Compound 3, half-maximal inhibitory concentration: 7.5 nM
Compound 3: middle estimate off by 2.5-fold (0.40 log units), on the low side, and the stated range covers the measured number.
By their numbers in this assay, from the lowest: compound 1; then compound 3; then compound 2.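

In this assay the group on the aromatic nitrogen now has a reading in one place: with the (4-fluorophenyl)amino group held fixed, 1-(cyclopropylsulfonyl)pyrrolidin-3-yl in place of 1-(tert-butoxycarbonyl)pyrrolidin-3-yl gives a 3.6-fold lower number from compound 2 to compound 3 (0.56 log units; beyond the scatter) as a modest gain. With the cyclopropylsulfonyl group held fixed, fluoro in place of hydrogen on an aromatic carbon gives a 4.7-fold higher number from compound 1 to compound 3 (0.67 log units; beyond the scatter) as a modest loss, so the two changes run in opposite directions around compound 3. No supporting data bear on why either step takes this direction or size. As far as these compounds go, whether the fluoro step keeps its size with 1-(tert-butoxycarbonyl)pyrrolidin-3-yl on the aromatic nitrogen stays open. Also open, from the compounds shown here alone, is how a methylsulfonyl or an acetyl group on the pyrrolidine nitrogen would compare with cyclopropylsulfonyl.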